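This account rests on a few compounds, and the source may have more. Where it says the series, first, only, none or still open, it means among the compounds named here.

Series notes. For the measured compounds named here, compound 1 `Cc1[nH]c2ccccc2c1C(c1ccccc1)c1cc2cc(Cl)ccc2o1` and compound 2 `COc1ccc2oc(C(c3ccccc3)c3c[nH]c4ccccc34)cc2c1` share the core but differ in more than one place, so no single step connects them. In a functional assay on SiHa cells (Homo sapiens) for cytotoxicity (a lower number here means a stronger inhibitor, a higher number a weaker inhibitor), compound 1 gives 47500 nM. For compound 2 this assay reports only a limit, > 100000 nM, not a number. Its position among the two values shown is given by the limit of > 100000 nM in this assay, at which 1 of the 2 values shown sits. Compound 3 `COc1ccc2oc(C(c3ccccc3)c3c(C)[nH]c4ccccc34)cc2c1` is not yet measured. It differs from compound 2 by methyl in place of hydrogen on an aromatic carbon. Going by the values given here, no measured step covers this change, so the data give neither its size nor its direction. Compound 1 carries the same methyl on its core and gives 47500 nM, but it differs from compound 2 at a second site as well. A step beyond the scatter is not expected with confidence. The estimated step of an at least 1.4-fold lower number from compound 2 to compound 3 (0.15 log units; that floor lies within the scatter) allows a modest gain. Compound 3 is expected to give about 70000 nM in this assay, within 25000 nM to 200000 nM, with a real chance that only a limit is reported.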

Compound 3, half-maximal inhibitory concentration: > 100000 nM
Compound 3 ended at the assay's limit; the forecaster's own chance of this, stated with the estimate: 45%; at least 1.4-fold (0.15 log units) between middle value and limit.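

In this assay the methyl on the aromatic carbon next to the ring nitrogen does not bring the methoxy compound to a measurable value: compound 3 reports only a limit, as compound 2 does, so the step between them cannot be read. With the methyl present in both compounds, methoxy in place of chloro on an aromatic carbon gives an at least 2.1-fold higher number from compound 1 to compound 3 (0.32 log units; beyond the scatter), so the methyl alone does not carry the measurable value of compound 1. Most of the series now stands at a limit rather than a number: the limit of > 100000 nM in this assay, at which 2 of the 3 values shown sit.

What the methyl contributes with chloro in place remains open, as the compounds shown give no step for it. Also open, going by these compounds, is whether an ethyl group or an amine at this position, or a nitrile in place of the chloro, would give a value that can be read.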